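A few compounds are considered here, and "the series" means these few. Any claim that something is new, unique, unknown or untested is made for them only; others in the source may bear on it.

In an assay on isolated protein for inhibition of tyrosine-protein kinase receptor UFO (Homo sapiens), read by LC-MS (a higher number here means a weaker inhibitor, a lower number a stronger inhibitor), compound 1 `COc1cc(-c2c(C)nn(C)c2C)ccc1-c1nnc(N(C)Cc2ccc3nccn3c2)o1` gives 794 nM, and compound 2 `Cc1cc(-c2c(C)nn(C)c2C)ccc1-c1nnc(N(C)Cc2ccc3nccn3c2)o1` gives 79.4 nM. Compound 2 holds the lowest of the two numbers; its nearest neighbour is compound 1, separated by a 10-fold lower number from compound 1 to compound 2 (1.00 log units; beyond the scatter) on a methyl in place of methoxy on an aromatic carbon. Compound 3 `Cc1cc(-c2c(C)nc(C)n2C)ccc1-c1nnc(N(C)Cc2ccc3nccn3c2)o1` differs from compound 2 by 1,2,4-trimethyl-1H-imidazol-5-yl in place of 1,3,5-trimethyl-1H-pyrazol-4-yl on an aromatic carbon. Among the measured compounds shown here, no measured step bears on this exchange, so the single methyl-for-methoxy step gives no guidance, and a step of no more than the scatter, in either direction, is expected: a 1.3-fold higher number from compound 2 to compound 3 (0.10 log units; within the scatter). Compound 3 is therefore estimated at 100 nM, within 40 nM to 300 nM.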

Compound 3, half-maximal inhibitory concentration: 3980 nM
Compound 3: the middle estimate sits 40-fold (1.60 log units) below what was measured; the measured number lies above the stated range.
By their numbers in this assay, from the lowest: compound 2; then compound 1; then compound 3.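

The aromatic carbon para to a large group does not tolerate every five-membered ring: in this assay, two groups with identical atoms and counts give a 50-fold higher number from compound 2 to compound 3 (1.70 log units; beyond the scatter). Matching heavy atoms, hetero atoms, hydrogen-bond acceptors and charge therefore does not make these groups interchangeable at this position. No available evidence accounts for the difference.

Open, going by these compounds, is whether the arrangement of the ring nitrogens or the placement of the methyl groups decides the result. A pyrazol-4-yl without methyl groups, or a plain phenyl, at this carbon would bear on that.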